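The source may hold more compounds than are shown below. What is called first, only, known or untested is meant among the compounds shown, and "the series" means these compounds.

Compound 1 `CCN1CCN(C(=S)SCCCOc2ccc3c(=O)c(-c4ccc(OC)cc4)coc3c2)CC1`: 36900 nM
Compound 2 `COc1ccc(-c2coc3cc(OCCCSC(=S)N4CCN(c5ccccn5)CC4)ccc3c2=O)cc1`: 38300 nM

In a functional assay on ECa-109 cells for inhibition, with ECa-109 cell line (Homo sapiens) as the target, read by MTT assay, with a stated time of 48 h (a higher number here means a weaker inhibitor, a lower number a stronger inhibitor), compound 2 gives 38300 nM and stands level with compound 1 within the usual scatter. The next structure, compound 3 `COc1ccc(-c2coc3cc(OCCCSC(=S)N4CCCC4)ccc3c2=O)cc1`, has pyrrolidin-1-yl in place of 4-(pyridin-2-yl)piperazin-1-yl on a thiocarbonyl carbon.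

For the measured compounds named here, only one measured step bears on this change: a 1.0-fold higher number from compound 1 to compound 2 (0.02 log units; within the scatter). There, pyridin-2-yl replaced ethyl on an amine nitrogen in a ring, and the number stayed within the scatter. Going by the values given here, that is thin evidence, since the ring itself stayed in place and no measured pair shows what happens when it is exchanged. No clear direction can therefore be drawn, and no change beyond the scatter is expected in this assay. The expected size is a 1.3-fold lower number from compound 2 to compound 3 (0.11 log units; within the scatter). For compound 3 the estimate is 30000 nM, with an expected range of 10000 nM to 70000 nM.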

Compound 3, half-maximal inhibitory concentration: 30800 nM
For compound 3 the middle estimate is 1.0-fold (0.01 log units) below the measured one, within the range that was stated.
By their numbers in this assay, from the lowest: compounds 3, 1 and 2 (each within the scatter of the next).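

In this assay, for the compounds shown here, the earlier compounds changed only a group on an amine nitrogen in a ring, whereas here the ring itself is exchanged: pyrrolidin-1-yl on the thiocarbonyl carbon gives a 1.2-fold lower number from compound 2 to compound 3 (0.09 log units; within the scatter) and a 1.2-fold lower number from compound 1 to compound 3 (0.08 log units; within the scatter). A five-membered ring with one hetero atom and far fewer heavy atoms can therefore take the place of either piperazine-based group with no change beyond the scatter. No measurement in hand offers a reason for this result.

On these data alone, all three compounds lie within the scatter of their neighbours, so it remains open whether any group on this thiocarbonyl carbon can move the number beyond it. A morpholine ring or an open-chain diethylamino group there could test this, while a longer chain linking the sulfur to the shared core would probe a different part of the molecule.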